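Swapping a ring methyl for hydroxy: an expected drop

The source may hold more compounds than are shown below. What is called first, only, known or untested is meant among the compounds shown, and "the series" means these compounds.

Three compounds have been measured in a physicochemical assay for lipophilicity, at pH 7.4; on this read-out lower numbers stand for lower lipophilicity and higher numbers for higher lipophilicity:

Compound 1 `CC(C)CN(Cc1ccccc1C(F)(F)F)S(=O)(=O)c1ccc2c(c1)C(O)CC(C1CCOCC1)O2`: 4.23
Compound 2 `CCc1ccc(N(Cc2ccccc2)S(=O)(=O)c2ccc3c(c2)C(O)CC(C2CCOCC2)O3)cc1`: 4.68
Compound 3 `CCc1ccc(N(CC(C)C)S(=O)(=O)c2ccc3c(c2)C(C)CC(C2CCOCC2)O3)cc1`: 5.71

Compound 3 gives the highest number of the three. Its nearest neighbour is compound 2, whose value is lower by a gap beyond the usual scatter, and compound 1 sits furthest away, lower still and again beyond the scatter. Going by the values given here, no two of these measured compounds differ in only one place, so no single measured step is available for direct comparison.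

Compound 4 `CCc1ccc(N(CC(C)C)S(=O)(=O)c2ccc3c(c2)C(O)CC(C2CCOCC2)O3)cc1` is the next compound to be measured. It differs from compound 3 in one place: hydroxy in place of methyl on a saturated ring carbon. The two hydroxy-bearing compounds already measured both sit well below compound 3, as compound 1 gives 4.23 and compound 2 gives 4.68 in this assay, which makes a downward step beyond the scatter the expected outcome here. The step from compound 3 to compound 4 in this assay is expected to be a number 1.21 log units lower from compound 3 to compound 4 (beyond the scatter). Compound 4 is therefore estimated to give 4.5 in this assay, with a plausible range from 3.9 to 5.1.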

Compound 4, distribution coefficient: 4.12
For compound 4 the middle estimate is 0.38 log units above the measured one; the measured number falls inside the stated range.
By their numbers in this assay, from the lowest: compounds 4 and 1 (each within the scatter of the next); then compound 2; then compound 3.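

In this assay, going by these compounds alone, hydroxy in place of methyl on this saturated ring carbon, with all else unchanged, gives a number 1.59 log units lower from compound 3 to compound 4 (beyond the scatter) as the first direct reading of this change at this position. With the hydroxy kept, changing the sulfonamide side can still shift the number: isopropyl in place of phenyl on the saturated chain carbon bound to the sulfonamide nitrogen gives a number 0.56 log units lower from compound 2 to compound 4 (beyond the scatter) as a modest step. By contrast, 4-ethylphenyl in place of 2-(trifluoromethyl)benzyl on that nitrogen gives a number 0.11 log units lower from compound 1 to compound 4 (within the scatter) and so shows no clear shift.

The compounds shown leave open how a methoxy group or an amine on this same ring carbon would read, and whether hydroxy for methyl gives a similar step with other sulfonamide groups. Nothing measured here gives a reason for the size of this step.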